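This account rests on a few compounds, and the source may have more. Where it says the series, first, only, none or still open, it means among the compounds named here.

Working notes on the sulfonamide series with a shared thiourea-linked core.

Compound 1 `Cc1noc(NS(=O)(=O)c2ccc(N/C(S)=N\c3ccnc4cc(C(F)(F)F)ccc34)cc2)c1C` gives 27700 nM in a functional assay on HT-1080 cells (Homo sapiens) for antiproliferative activity, read by sulforhodamine B assay, with a stated time of 48 h; on this read-out higher numbers stand for weaker inhibition and lower numbers for stronger inhibition. Compound 2 `O=S(=O)(Nc1ccccn1)c1ccc(N/C(S)=N\c2ccnc3cc(C(F)(F)F)ccc23)cc1` gives 28000 nM in this assay, and compound 3 `Cc1ccnc(NS(=O)(=O)c2ccc(N/C(S)=N\c3ccnc4cc(C(F)(F)F)ccc34)cc2)n1` gives 28700 nM. The three groups on the sulfonamide nitrogen leave the read-out essentially untouched: a 1.0-fold higher number from compound 1 to compound 2 (0.00 log units; within the scatter), a 1.0-fold higher number from compound 1 to compound 3 (0.02 log units; within the scatter) and a 1.0-fold higher number from compound 2 to compound 3 (0.01 log units; within the scatter) are all within the scatter. Compound 3 therefore stands level with compounds 1 and 2; its number cannot be separated from theirs.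

Compound 4 `COc1cc(NS(=O)(=O)c2ccc(N/C(S)=N\c3ccnc4cc(C(F)(F)F)ccc34)cc2)nc(OC)n1` carries the change (2,6-dimethoxypyrimidin-4-yl in place of 4-methylpyrimidin-2-yl on a sulfonamide nitrogen). Among the compounds with values here, the steps that bear on this exchange are those already made at the same place, a 1.0-fold higher number from compound 2 to compound 3 (0.01 log units; within the scatter) and a 1.0-fold higher number from compound 1 to compound 3 (0.02 log units; within the scatter), both flat, so the aryl group on the sulfonamide nitrogen has so far not moved the number. No step beyond the scatter is expected in this assay, and the estimated step is a 1.0-fold lower number from compound 3 to compound 4 (0.00 log units; within the scatter). Compound 4 is expected to give about 28500 nM, with a range from 13000 nM to 60000 nM.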

Compound 4, half-maximal inhibitory concentration: 29500 nM
Estimate against measurement, compound 4: 1.0-fold (0.01 log units) below, and the stated range covers the measured number.
By their numbers in this assay, from the lowest: compounds 1, 2, 3 and 4 (each within the scatter of the next).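

The 2,6-dimethoxypyrimidin-4-yl group leaves the read-out level in this assay (a 1.0-fold higher number from compound 3 to compound 4 (0.01 log units; within the scatter); a 1.1-fold higher number from compound 2 to compound 4 (0.02 log units; within the scatter); a 1.1-fold higher number from compound 1 to compound 4 (0.03 log units; within the scatter)). Within the data shown here, this extends the flat picture at the sulfonamide nitrogen to a larger exchange than the earlier steps: from compound 3 to compound 4, the group goes from 7 to 10 heavy atoms and from 2 to 4 hydrogen-bond acceptors, and oxygen enters it, with no step beyond the scatter. No supporting data bear on why this position stays flat.

From the compounds shown here alone, all four compounds carry a six-membered or five-membered aromatic ring on the sulfonamide nitrogen, so it stays open whether an aminoethyl group or a longer chain ending in a carboxylic acid would move the number. Going by these compounds, whether changes to the shared core would move it also stays open, as that core is the same throughout.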